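Fluoro in place of hydroxy on compound 2

The source may report more compounds than this note shows. Statements on the series, on what has been measured and on what is new or still open speak of the compounds shown alone.

Values measured so far in a functional assay on SMMC-7721 cells (Homo sapiens) for cytotoxicity, read by MTT assay, with a stated time of 72 h (on this read-out lower numbers stand for stronger inhibition and higher numbers for weaker inhibition), are these:
- compound 1 `CCC(C)=C1C(=O)N(c2ccc(Cl)cc2)N(c2ccc(Cl)cc2)C1=O` at 49200 nM
- compound 2 `O=C1C(=Cc2ccc(O)cc2)C(=O)N(c2ccc(Cl)cc2)N1c1ccc(Cl)cc1` at 20600 nM

The gap between the two lies beyond the scatter, and compound 2 at 20600 nM has the lower number and so the stronger inhibition. Compound 3 `O=C1C(=Cc2ccc(F)cc2)C(=O)N(c2ccc(Cl)cc2)N1c1ccc(Cl)cc1` has not yet been measured. It carries fluoro in place of hydroxy on an aromatic carbon, para to a large group (fluoro in place of hydroxy on an aromatic carbon). Within the data shown here, no measured pair isolates this change, so the expectation rests only on compound 2 at 20600 nM as the closest measured structure. In this assay no step beyond the scatter is expected, and no direction can be argued from the data. The expected change is a 1.1-fold lower number from compound 2 to compound 3 (0.06 log units; within the scatter) and would stay within the scatter. For compound 3 the expected value is 18000 nM (estimated range 7000 nM to 50000 nM).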

Compound 3, half-maximal inhibitory concentration: 23300 nM
Estimate against measurement, compound 3: 1.3-fold (0.11 log units) below, within the range that was stated.
By their numbers in this assay, from the lowest: compounds 2 and 3 (each within the scatter of the next); then compound 1.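

In this assay, among these compounds, fluoro in place of hydroxy on an aromatic carbon, para to a large group, gives a 1.1-fold higher number from compound 2 to compound 3 (0.05 log units; within the scatter) and is the first single-place comparison. Fluoro carries none of the hydrogen-bond donors or acceptors counted for hydroxy, yet compound 2 and compound 3 stand within the scatter of each other, so the hydroxy is not needed at this position to hold this level of the read-out. No supporting measurement bears on this result, and it stands without an explanation.

From the compounds shown here alone, whether an amine or a carboxylic acid at this position would read differently from hydroxy and fluoro stays open. Also open, going by these compounds, is whether any group here can move the number beyond the scatter.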